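A ring swap on compound 2

The source may hold more compounds than are shown below. What is called first, only, known or untested is meant among the compounds shown, and "the series" means these compounds.

- Compound 1 `CCNC(=O)Nc1nc2cc(-c3cccnc3)c(=O)n(CC)c2s1`: 94000 nM
- Compound 2 `CCNC(=O)Nc1nc2cc(-c3cccnc3)c(=O)n(C(C)C)c2s1`: 42000 nM
- Compound 3 `CCNC(=O)Nc1nc2cc(-c3cccnc3)c(=O)n(C(C)C(=O)O)c2s1`: 7290000 nM

In a physicochemical assay for solubility, in phosphate buffer, at pH 7.4 (on this read-out lower numbers stand for lower solubility and higher numbers for higher solubility), compound 2 has the lowest number of the three. Its closest neighbour is shown by a 2.2-fold lower number from compound 1 to compound 2 (0.35 log units; beyond the scatter), its furthest by a 170-fold higher number from compound 2 to compound 3 (2.24 log units; beyond the scatter). Compound 4 `CCNC(=O)Nc1nc2cc(-c3cncnc3)c(=O)n(C(C)C)c2s1` has one change: pyrimidin-5-yl in place of pyridin-3-yl on an aromatic carbon. Going by the values given here, no measured step touches this group, so the evidence is indirect. The steps with a carboxy group are large, as in a 78-fold higher number from compound 1 to compound 3 (1.89 log units; beyond the scatter), but compound 4 gains no carboxy group. The modest 2.2-fold lower number from compound 1 to compound 2 (0.35 log units; beyond the scatter) is the better guide to size, so only a small rise is expected, perhaps none beyond the scatter. The expected change is a 1.4-fold higher number from compound 2 to compound 4 (0.15 log units; within the scatter). For compound 4 the estimate is 60000 nM, with an expected range of 25000 nM to 150000 nM.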

Compound 4, solubility: 7000 nM
Compound 4: middle estimate off by 8.6-fold (0.93 log units), on the high side, and the stated range ends above it.
By their numbers in this assay, from the lowest: compound 4; then compound 2; then compound 1; then compound 3.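

In this assay there is a 6.0-fold lower number from compound 2 to compound 4 (0.78 log units; beyond the scatter), so pyrimidin-5-yl in place of pyridin-3-yl moves the number beyond the scatter, and compound 4 now has the lowest number of the four. Going by these compounds alone, the earlier steps changed only the group on the ring nitrogen, so this is the first sign that the aromatic carbon carrying this ring also matters. Nothing measured here explains the drop.

On these data alone, whether the same swap would lower the number in compound 1 or compound 3 stays open. So does the outcome with a plain phenyl ring or an amine at this position.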